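Triazole nitrogen substituent swaps: cytotoxicity working notes

The compounds below may be only part of what the source reports. "The series", "measured", "known", "first", "only" and "open" are said of these compounds alone.

Measured compounds:
compound 1 `COc1ccc(/C=C\C(=O)O)c(OCc2cn(-c3ccc(C#N)cc3)nn2)c1CC=C(C)C`: 21000 nM
compound 2 `COc1ccc(/C=C\C(=O)O)c(OCc2cn(-c3nc4ccccc4s3)nn2)c1CC=C(C)C`: 16400 nM

In a functional assay on HCT-116 cells (Homo sapiens) for cytotoxicity, read by MTT assay, with a stated time of 24 h (on this read-out higher numbers stand for weaker inhibition and lower numbers for stronger inhibition), compound 1 gives 21000 nM and compound 2 gives 16400 nM. Compound 2 holds the lowest of the two numbers, with compound 1 its nearest neighbour; the step of a 1.3-fold lower number from compound 1 to compound 2 (0.11 log units; within the scatter) is within the scatter, so the two cannot be ordered.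

Compound 3 `COc1ccc(/C=C\C(=O)O)c(OCc2cn(-c3ccccc3C#N)nn2)c1CC=C(C)C` differs from compound 2 in one place: 2-cyanophenyl in place of 1,3-benzothiazol-2-yl on an aromatic nitrogen. For the measured compounds named here, the only measured step that bears on this position, from compound 1 to compound 2, also exchanged the group on the aromatic nitrogen and stayed within the scatter; compound 1 already carries a cyanophenyl group there. No step beyond the scatter is therefore expected for compound 3, and the expected step is a 1.2-fold higher number from compound 2 to compound 3 (0.06 log units; within the scatter). The estimate for compound 3 in this assay is 19000 nM, expected to fall between 8000 nM and 45000 nM.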

Compound 3, half-maximal inhibitory concentration: 38300 nM
Compound 3: middle estimate off by 2.0-fold (0.30 log units), on the low side, and the stated range covers the measured number.
By their numbers in this assay, from the lowest: compounds 2, 1 and 3 (each within the scatter of the next, the first and the last beyond it).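

In this assay the group on the aromatic nitrogen now shows a step beyond the scatter, though a modest one: 2-cyanophenyl in place of 1,3-benzothiazol-2-yl gives a 2.3-fold higher number from compound 2 to compound 3 (0.37 log units; beyond the scatter), whereas the earlier exchange at this position stayed within the scatter. The place of the nitrile on the phenyl ring does not separate the two cyanophenyl compounds, since 2-cyanophenyl in place of 4-cyanophenyl gives a 1.8-fold higher number from compound 1 to compound 3 (0.26 log units; within the scatter) and that step lies within the scatter. No measurement at hand bears on what lies behind the step at this position.

Still open, going by these compounds, is how a longer alkyl chain or an amine on this nitrogen would compare with the aromatic groups. The three compounds also leave open whether the step holds on any other cell line.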